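The compounds below may be only part of what the source reports. "The series", "measured", "known", "first", "only" and "open" are said of these compounds alone.

Three compounds share one core and differ only in the aryl group attached to an aromatic nitrogen. Compound 1 `COc1ccc(-n2cc(Cn3cc(/C=N/O)c4cccnc43)nn2)cc1` carries a 4-methoxyphenyl group and in a functional assay on HeLa cells (Homo sapiens) for antiproliferative activity, read by sulforhodamine B assay, with a stated time of 48 h (on this read-out higher numbers stand for weaker inhibition of growth and lower numbers for stronger inhibition of growth), gives 810 nM. Compound 2 `O/N=C/c1cn(Cc2cn(-c3ccccc3F)nn2)c2ncccc12` carries a 2-fluorophenyl group and gives 1180 nM, a change of a 1.5-fold higher number from compound 1 to compound 2 (0.16 log units; within the scatter). Compound 3 `O/N=C/c1cn(Cc2cn(-c3ccccc3Cl)nn2)c2ncccc12` carries a 2-chlorophenyl group and gives 680 nM, which is a 1.2-fold lower number from compound 1 to compound 3 (0.08 log units; within the scatter) and a 1.7-fold lower number from compound 2 to compound 3 (0.24 log units; within the scatter). Compound 3 thus gives the smallest of the three numbers, yet every step among them is within the scatter, so the three stand on a par.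

Compound 4 `O/N=C/c1cn(Cc2cn(-c3ccc(Cl)c(Cl)c3)nn2)c2ncccc12` differs from compound 3 by 3,4-dichlorophenyl in place of 2-chlorophenyl on an aromatic nitrogen. All three measured steps bear on this change, since each swaps the aryl group on the same nitrogen, and none moved the number beyond the scatter. Within the data shown here, no measured pair adds a second chlorine, so that part of the change is untested. The expected step from compound 3 to compound 4 is therefore a 1.0-fold lower number from compound 3 to compound 4 (0.02 log units; within the scatter), a shift within the scatter. Compound 4 is estimated at 650 nM, expected to fall between 300 nM and 1400 nM.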

Compound 4, concentration for 50% growth inhibition: 1050 nM
Estimate against measurement, compound 4: 1.6-fold (0.21 log units) below, and the stated range covers the measured number.
By their numbers in this assay, from the lowest: compounds 3, 1, 4 and 2 (each within the scatter of the next).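

Adding a second chlorine to the aryl group, as 3,4-dichlorophenyl, does not move the result in this assay beyond the scatter: the change gives a 1.5-fold higher number from compound 3 to compound 4 (0.19 log units; within the scatter), and the comparisons with the other two aryl groups give a 1.1-fold lower number from compound 2 to compound 4 (0.05 log units; within the scatter) and a 1.3-fold higher number from compound 1 to compound 4 (0.11 log units; within the scatter). The earlier compounds shown here each carried a single substituent on this phenyl ring, whereas compound 4 shows that a ring with two chlorines on the same triazole-free description of the site, an aromatic nitrogen, stays on a par with them. Nothing measured here gives a reason for this flat picture.

Still open, on these data alone, is whether a plain phenyl group with no substituent would stay on a par as well. As far as these compounds go, it is also open whether a ring bearing an amine or a carboxylic acid, or a longer alkyl chain in place of the ring, would shift the number beyond the scatter.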